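From a Cyclobutyl Ether to a Pyridylpropyl Ether

The source may hold more compounds than are shown below. What is called first, only, known or untested is meant among the compounds shown, and "the series" means these compounds.

The three compounds measured so far, all sharing one core, and their results in an assay on cells for binding affinity to Neuropeptide Y receptor type 1 (Homo sapiens); a lower number here means a stronger inhibitor, a higher number a weaker inhibitor:

compound 1 `CCOc1cc(CCc2nc(C)c(CC)s2)nc(NCc2cc(Cl)cc(NC(=O)OC(C)C)c2)c1`: 33 nM
compound 2 `CCCCCCCOc1cc(CCc2nc(C)c(CC)s2)nc(NCc2cc(Cl)cc(NC(=O)OC(C)C)c2)c1`: 72 nM
compound 3 `CCc1sc(CCc2cc(OC3CCC3)cc(NCc3cc(Cl)cc(NC(=O)OC(C)C)c3)n2)nc1C`: 11 nM

Compound 3 stands lowest of these three numbers, and both of its steps to the others lie beyond the scatter: a 3.0-fold lower number from compound 1 to compound 3 (0.48 log units; beyond the scatter) and a 6.5-fold lower number from compound 2 to compound 3 (0.82 log units; beyond the scatter). The three differ only in the group carried by the oxygen on the aromatic ring. Compound 4 `CCc1sc(CCc2cc(OCCCc3cccnc3)cc(NCc3cc(Cl)cc(NC(=O)OC(C)C)c3)n2)nc1C` is the next compound in the series, and it changes exactly that group again: 3-(pyridin-3-yl)propyl in place of cyclobutyl on an oxygen on an aromatic ring.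

Among the measured compounds shown here, two measured steps bear on this change. Lengthening the chain on that oxygen gave a 2.2-fold higher number from compound 1 to compound 2 (0.34 log units; beyond the scatter), and replacing the long chain by the small ring gave a 6.5-fold lower number from compound 2 to compound 3 (0.82 log units; beyond the scatter). Both point the same way: the larger the group on that oxygen, the higher the number in this assay. For the measured compounds named here, the new group is larger again than cyclobutyl, so a higher number than that of compound 3 is expected, though the pyridine ring brings in a hydrogen-bond acceptor that none of the measured groups had, so this is uncertain. For compound 4 a step of a 3.2-fold higher number from compound 3 to compound 4 (0.50 log units; beyond the scatter) is expected, giving an estimate of 35 nM with a range from 12 nM to 110 nM.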

Compound 4, half-maximal inhibitory concentration: 6.5 nM
Compound 4: middle estimate off by 5.4-fold (0.73 log units), on the high side; measured number below the stated range.
By their numbers in this assay, from the lowest: compounds 4 and 3 (each within the scatter of the next); then compound 1; then compound 2.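

In this assay, the earlier trend of a larger group on this oxygen giving a higher number does not extend to compound 4: 3-(pyridin-3-yl)propyl has more heavy atoms than cyclobutyl, yet the change gives a 1.7-fold lower number from compound 3 to compound 4 (0.23 log units; within the scatter), so the two groups cannot be told apart here. The ring-bearing chain also compares well with the plain chains, with an 11-fold lower number from compound 2 to compound 4 (1.04 log units; beyond the scatter) and a 5.1-fold lower number from compound 1 to compound 4 (0.71 log units; beyond the scatter), so a large group at this position need not raise the number. No measurement shown here explains this result.

The compounds shown leave open whether the pyridine nitrogen matters or any ring at the end of the chain would do, a question that a 3-phenylpropyl group on the same oxygen would address. They also leave open how 2-(pyridin-3-yl)ethyl, with its shorter chain, would compare.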